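Replacing pyridin-4-yl with ethyl at the assay limit

The source may hold more compounds than are shown below. What is called first, only, known or untested is meant among the compounds shown, and "the series" means these compounds.

Compound 1 `CCOC(=O)c1ccc(-c2nn(Cc3cccc(Cl)c3)c3ccccc23)cc1`: > 10000 nM (a limit)
Compound 2 `CCOC(=O)c1ccc(-c2nn(Cc3ccc(Cl)cc3)c3ccccc23)cc1`: > 10000 nM (a limit)
Compound 3 `CCOC(=O)c1ccc(-c2nn(Cc3ccncc3)c3ccccc23)cc1`: > 10000 nM (a limit)

In a functional assay on cells (Platelet, Homo sapiens) for inhibition (a lower number here means a stronger inhibitor, a higher number a weaker inhibitor), compound 3 gives > 10000 nM, which is a limit and not a number. It shares its place with compound 1 and compound 2, all three standing at the limit of > 10000 nM in this assay, at which 3 of the 3 values shown sit.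

Compound 4 `CCCn1nc(-c2ccc(C(=O)OCC)cc2)c2ccccc21` keeps the shared core and differs from compound 3 at one place: ethyl in place of pyridin-4-yl on a saturated chain carbon bound to an aromatic nitrogen.

Three measured changes at this same place bear on the new one: a step that the two limits leave unreadable from compound 1 to compound 2, a step that the two limits leave unreadable from compound 1 to compound 3 and a step that the two limits leave unreadable from compound 2 to compound 3. None of them gives a size to carry over, and none of the three groups tried there brought a compound off the limit. No step beyond the scatter is therefore expected in this assay, and no direction can be named. The expected change is a step that the limit leaves unreadable from compound 3 to compound 4. For compound 4 the estimated value is 15000 nM, with an expected range from 4000 nM to 50000 nM.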

Compound 4, half-maximal inhibitory concentration: > 10000 nM
Compound 4: a limit, no number; the forecaster's own chance of this, stated with the estimate: 85%; the middle value does not contradict the limit.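

In this assay compound 4 gives > 10000 nM, which is a limit and not a number. Its steps from compound 1, compound 2 and compound 3 therefore cannot be read. The compounds shown leave open whether any group at this place would bring a compound off the limit: the limit of > 10000 nM in this assay, at which 4 of the 4 values shown sit.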